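Methyl to hydrogen on a ring amine: a short series

The source may report more compounds than this note shows. Statements on the series, on what has been measured and on what is new or still open speak of the compounds shown alone.

Compound 1 `CN1CC[C@@H]2CC[C@H](O)C[C@@H]21` was tested in an assay on HEK293 cells for displacement of a labelled ligand from Neuronal acetylcholine receptor; alpha3/beta4 (Rattus norvegicus), with a stated time of 4 h; on this read-out lower numbers stand for stronger inhibition and higher numbers for weaker inhibition. Compound 1 gives > 300000 nM, which is a limit of the assay. Compound 2 `O[C@H]1CC[C@H]2CCN[C@H]2C1` carries hydrogen in place of methyl on an amine nitrogen in a ring. In this assay compound 2 gives > 300000 nM, again a limit. The step that the two limits leave unreadable from compound 1 to compound 2 therefore cannot be sized, both values sitting at the limit of > 300000 nM in this assay, at which 3 of the 3 values shown sit. Compound 3 `CN1CCC2=CC[C@H](O)C[C@@H]21` has another core; the difference between the two cores is not broken down here. In this assay compound 3 gives > 300000 nM, also a limit. Among the measured compounds shown here, compound 4 `O[C@H]1CC=C2CCN[C@H]2C1` is not yet measured and carries hydrogen in place of methyl on an amine nitrogen in a ring; this is the same kind of change as the one from compound 1 to compound 2, where the place is further described as two ring bonds from the ring atom that bears a fused ring. With every shown value at the limit of > 300000 nM in this assay, at which 3 of the 3 values shown sit, no readable step exists, and the expected step is a step that the limit leaves unreadable from compound 3 to compound 4. Compound 4 is estimated to give 500000 nM, most likely once more only a limit.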

Compound 4, inhibition constant: > 300000 nM
Compound 4 ended at the assay's limit; the forecaster's own chance of this, stated with the estimate: 90%; the middle value is on the limit's open side.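

No step can be read from compound 3 to compound 4, because both values are limits: the limit of > 300000 nM in this assay, at which 4 of the 4 values shown sit.

The compounds shown leave open whether hydrogen in place of methyl on the ring amine changes binding in this assay at all.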